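Working notes on the shared core: compound 2 to compound 4

The compounds below may be only part of what the source reports. "The series", "measured", "known", "first", "only" and "open" are said of these compounds alone.

Compound 1, `Cc1[nH]n(-c2nc3ccccc3n2C)c(=O)c1C`: in an assay on isolated protein for inhibition of alpha-ketoglutarate-dependent dioxygenase alkB homolog 3 (Homo sapiens), read by polymerase chain reaction, with a stated time of 1 h (a higher number here means a weaker inhibitor, a lower number a stronger inhibitor), compound 1 gives > 10000 nM, which is a limit of the assay rather than a number.
Compound 2, `COc1ccc(Cc2c(C)[nH]n(-c3nc4ccccc4[nH]3)c2=O)cc1`: in this assay compound 2 gives 630 nM.
Compound 3, `Cc1[nH]n(-c2nc3ccccc3[nH]2)c(=O)c1Cc1ccc(C(F)(F)F)cc1`: in this assay compound 3 gives 550 nM.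

Going by the values given here, compound 2 stands highest of the two numbers, with compound 3 nearest at a 1.1-fold lower number from compound 2 to compound 3 (0.06 log units; within the scatter); the only other value shown is the limit (the limit of > 10000 nM in this assay, at which 1 of the 3 values shown sits). Compound 4, `Cc1[nH]n(-c2nc3ccccc3[nH]2)c(=O)c1Cc1cccc(Cl)c1`, differs from compound 2 by 3-chlorophenyl in place of 4-methoxyphenyl on a saturated chain carbon bound to an aromatic carbon. Among the compounds with values here, the one measured step that bears on this, the change from compound 2 to compound 3, altered a group on the same benzyl ring and stayed within the scatter, so no step beyond the scatter is expected here either. Compound 4 is therefore expected at 600 nM, within 250 nM to 1500 nM, an expected step of a 1.1-fold lower number from compound 2 to compound 4 (0.02 log units; within the scatter).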

Compound 4, half-maximal inhibitory concentration: 540 nM
The estimate for compound 4 lay 1.1-fold (0.05 log units) above the measured number, within the range that was stated.
By their numbers in this assay, from the lowest: compounds 4, 3 and 2 (each within the scatter of the next). At a limit, above all of these: compound 1.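

In this assay 3-chlorophenyl in place of 4-methoxyphenyl on a saturated chain carbon bound to an aromatic carbon gives a 1.2-fold lower number from compound 2 to compound 4 (0.07 log units; within the scatter) and thus adds a second change on the benzyl ring that stays within the scatter. Unlike the trifluoromethyl-for-methoxy step, this change also alters the numbered place of the ring substituent and removes the hydrogen-bond acceptor from the group. Nothing shown gives a cause for this step.

Open, going by these compounds, is whether an amine or a carboxylic acid on the benzyl ring, or a longer chain in place of the saturated chain carbon, would give a step beyond the scatter.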